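Aziridinyl amide in place of carboxamide: plasma stability outlook

The compounds below may be only part of what the source reports. "The series", "measured", "known", "first", "only" and "open" are said of these compounds alone.

Compound 1 `CCNC(=O)c1cc(N)c(Nc2ccc(C#N)cc2)cc1Oc1c(C)cc(/C=C/C#N)cc1C` gives 91 h in an ADME assay on a cell-free system (plasma, Homo sapiens) for metabolic stability, read by LC-MS, tested at 10 ug/mL; a lower number here means that the compound disappears faster, a higher number that the compound lasts longer.
Compound 2 `Cc1cc(/C=C/C#N)cc(C)c1Oc1cc(Nc2ccc(C#N)cc2)c(N)cc1C(N)=O` gives 65 h in this assay.

In this assay compound 2 stands lowest of the two numbers, and its nearest neighbour is compound 1, whose number is higher by an amount within the scatter. Within the data shown here, the one measured step, a 1.4-fold lower number from compound 1 to compound 2 (0.15 log units; within the scatter), swaps ethyl for hydrogen on the amide-type nitrogen and moves the half-life only within the usual scatter.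

Compound 3 `Cc1cc(/C=C/C#N)cc(C)c1Oc1cc(Nc2ccc(C#N)cc2)c(N)cc1C(=O)N1CC1` differs from compound 2 at the same carbonyl: aziridin-1-yl in place of amino on a carbonyl carbon. Among the measured compounds shown here, the only step that bears on this position is the one from compound 1 to compound 2, which altered the group on the amide nitrogen and changed little. On that basis the account expects the change from compound 2 to compound 3 to stay within the scatter as well, with no clear direction, so a 1.1-fold lower number from compound 2 to compound 3 (0.03 log units; within the scatter) is the estimated step. Compound 3 is therefore expected to give about 60 h in this assay, estimated to fall between 25 h and 130 h.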

Compound 3, half-life: 12 h
Beside the measured number, compound 3's estimate is 5.0-fold (0.70 log units) above it; the whole stated range lies above it.
By their numbers in this assay, from the lowest: compound 3; then compounds 2 and 1 (each within the scatter of the next).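

Among these compounds, the carbonyl position is not as indifferent as the earlier compounds suggested: in this assay, aziridin-1-yl in place of amino on a carbonyl carbon gives a 5.4-fold lower number from compound 2 to compound 3 (0.73 log units; beyond the scatter) and so moves the half-life beyond the scatter, while the change from ethyl to hydrogen on the amide-type nitrogen gave only a 1.4-fold lower number from compound 1 to compound 2 (0.15 log units; within the scatter) and stayed within it. Aziridin-1-yl in place of ethylamino points the same way, with a 7.6-fold lower number from compound 1 to compound 3 (0.88 log units; beyond the scatter) on the same shared core, so compound 3 stands below both other compounds in this set whichever of them it is set against. Nothing given here accounts for this drop in half-life.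

The three compounds do not separate the three-membered ring itself from the loss of the amide hydrogen, as compound 3 is the only one that differs from the others in both respects. From the compounds shown here alone, a dimethylamino, azetidin-1-yl or pyrrolidin-1-yl group on the same carbonyl carbon would bear on that question, and how such amides would fare in this assay remains open.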